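Chlorines in Place of Methyls on the Urea Aryl

The compounds below may be only part of what the source reports. "The series", "measured", "known", "first", "only" and "open" are said of these compounds alone.

Measured so far:
compound 1 `O=C(Nc1ccc(Br)cc1)Nc1ccc(Nc2ncnc3c2OCCN3)cc1` — 2220 nM
compound 2 `Cc1cc(C)cc(NC(=O)Nc2ccc(Nc3ncnc4c3OCCN4)cc2)c1` — 1070 nM

In an assay on isolated protein for inhibition of proto-oncogene tyrosine-protein kinase receptor Ret (Homo sapiens), read by 33P incorporation, with stated times of 15 min and 40 min (a lower number here means a stronger inhibitor, a higher number a weaker inhibitor), compound 2 gives 1070 nM, the lowest of the two numbers; its nearest neighbour, compound 1, gives 2220 nM. For the measured compounds named here, the only measured step, a 2.1-fold lower number from compound 1 to compound 2 (0.32 log units; beyond the scatter), changed the aryl group on the same amide-type nitrogen and was modest. Compound 3 `O=C(Nc1ccc(Nc2ncnc3c2OCCN3)cc1)Nc1cc(Cl)cc(Cl)c1` differs from compound 2 by 3,5-dichlorophenyl in place of 3,5-dimethylphenyl on an amide-type nitrogen. That single step gives little guidance on this exchange, so a step no larger than modest is expected, a 1.3-fold lower number from compound 2 to compound 3 (0.13 log units; within the scatter). Compound 3 is estimated at 800 nM, within 300 nM to 2500 nM.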

Compound 3, half-maximal inhibitory concentration: 865 nM
Beside the measured number, compound 3's estimate is 1.1-fold (0.03 log units) below it; the range from low to high includes it.
By their numbers in this assay, from the lowest: compounds 3 and 2 (each within the scatter of the next); then compound 1.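

Swapping 3,5-dimethylphenyl for 3,5-dichlorophenyl on the amide-type nitrogen (a 1.2-fold lower number from compound 2 to compound 3 (0.09 log units; within the scatter)) leaves compound 2 and compound 3 indistinguishable in this assay, so this exchange of methyls for chlorines does not separate them. Compound 3 also stands clear of the 4-bromophenyl compound (a 2.6-fold lower number from compound 1 to compound 3 (0.41 log units; beyond the scatter)), so both 3,5-disubstituted aryl compounds now differ from compound 1 beyond the scatter. No accompanying data bear on this result.

Open, from the compounds shown here alone, is how an aryl group carrying an amine or a carboxylic acid would compare on this nitrogen. Also open, going by these compounds, is whether a longer chain in place of the aryl group would be tolerated.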